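Series notes: 2-methoxyphenyl to 2-chlorophenyl on the shared core

The compounds below may be only part of what the source reports. "The series", "measured", "known", "first", "only" and "open" are said of these compounds alone.

Three compounds of this series carry the same core and differ only in the group on one phenyl ring. Compound 1 `Cc1noc2c(C(c3ccccc3)c3c(-c4ccccc4)c[n+]([O-])c4c(C)noc34)c(-c3ccccc3)c[n+]([O-])c12` gives 31.9 ug/mL in a functional assay on MCF7 cells (Homo sapiens) for cytotoxicity, read by MTT assay, with a stated time of 48 h; a higher number here means a weaker inhibitor, a lower number a stronger inhibitor. Compound 2 `Cc1ccccc1C(c1c(-c2ccccc2)c[n+]([O-])c2c(C)noc12)c1c(-c2ccccc2)c[n+]([O-])c2c(C)noc12` gives 60.7 ug/mL in this assay. Compound 3 `COc1ccccc1C(c1c(-c2ccccc2)c[n+]([O-])c2c(C)noc12)c1c(-c2ccccc2)c[n+]([O-])c2c(C)noc12` gives 57.4 ug/mL in this assay. Compound 3 thus holds the second highest of the three numbers, but the steps of a 1.8-fold higher number from compound 1 to compound 3 (0.26 log units; within the scatter) and a 1.1-fold lower number from compound 2 to compound 3 (0.02 log units; within the scatter) are both within the scatter, so no order among the three can be read from these numbers. The remaining step, a 1.9-fold higher number from compound 1 to compound 2 (0.28 log units; within the scatter), is likewise within the scatter.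

Compound 4 `Cc1noc2c(C(c3ccccc3Cl)c3c(-c4ccccc4)c[n+]([O-])c4c(C)noc34)c(-c3ccccc3)c[n+]([O-])c12` is not yet measured. Its difference from compound 3 is chloro in place of methoxy on an aromatic carbon. The three measured steps all concern this same aromatic carbon: hydrogen, methyl and methoxy at that place gave numbers within the scatter of one another. None of them involves chloro, so the step to compound 4 rests on analogy alone. Given that the prior changes at this place, including a 1.1-fold lower number from compound 2 to compound 3 (0.02 log units; within the scatter), stayed within the scatter, the step of a 1.1-fold lower number from compound 3 to compound 4 (0.06 log units; within the scatter) is expected to stay within the scatter too. Compound 4 is therefore estimated at 50 ug/mL, with a range from 25 ug/mL to 100 ug/mL.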

Compound 4, half-maximal inhibitory concentration: 72.1 ug/mL
The estimate for compound 4 lay 1.4-fold (0.16 log units) below the measured number; the measured number falls inside the stated range.
By their numbers in this assay, from the lowest: compounds 1, 3, 2 and 4 (each within the scatter of the next, the first and the last beyond it).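

With chloro on this aromatic carbon, ortho to a large group, the position gives its first step beyond the scatter: a 2.3-fold higher number from compound 1 to compound 4 (0.35 log units; beyond the scatter) for chloro in place of hydrogen. Against the other two substituted compounds chloro does not separate, since a 1.3-fold higher number from compound 3 to compound 4 (0.10 log units; within the scatter) and a 1.2-fold higher number from compound 2 to compound 4 (0.07 log units; within the scatter) are both within the scatter, so chloro, methoxy and methyl cannot be ordered among themselves at this place. Only compound 4 parts from the unsubstituted compound 1 beyond the scatter, while compound 2 and compound 3 stay within it, and this one pair is all that supports any effect of substitution here.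

As far as these compounds go, whether other groups on this aromatic carbon, such as an amine, a carboxylic acid or a longer alkyl chain, would follow chloro or stay with hydrogen remains open, as does the outcome of the same chloro change elsewhere on that ring. Nothing available for the series bears on why these numbers differ.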